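From methylsulfanyl to octylsulfanyl: the step to compound 3

The source may hold more compounds than are shown below. What is called first, only, known or untested is meant among the compounds shown, and "the series" means these compounds.

Compound 1 `CCn1c(SCc2ccccc2)nnc1-c1cc([N+](=O)[O-])cc([N+](=O)[O-])c1`: > 30000 nM
Compound 2 `CSc1nnc(-c2cc([N+](=O)[O-])cc([N+](=O)[O-])c2)n1Cc1ccccc1`: > 30000 nM
Compound 3 `CCCCCCCCSc1nnc(-c2cc([N+](=O)[O-])cc([N+](=O)[O-])c2)n1Cc1ccccc1`: not yet measured

In an ADME assay on HepG2 cells (Homo sapiens) for cytotoxicity, with a stated time of 48 h (on this read-out lower numbers stand for stronger inhibition and higher numbers for weaker inhibition), compound 1 gives > 30000 nM, which is a limit of the assay and not a number. Compound 2 likewise gives > 30000 nM, also a limit. Compound 2 therefore has no exact value, and the two measured compounds share (the limit of > 30000 nM in this assay, at which 2 of the 2 values shown sit).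

Compound 3 keeps the core of compound 2 and changes only the chain on sulfur, with methylsulfanyl becoming octylsulfanyl. The difference is heptyl in place of hydrogen on a saturated chain carbon bound to a sulfur.

Among the compounds with values here, no measured step guides the size of the change in this assay, so the expectation is cautious. A modest move towards stronger inhibition is expected, or no change beyond the scatter, and the assay may well report a limit again. The expected step is an at least 1.2-fold lower number from compound 2 to compound 3 (0.07 log units; that floor lies within the scatter). Compound 3 is estimated at 25000 nM, with an expected range from 9000 nM to 60000 nM.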

Compound 3, half-maximal inhibitory concentration: > 30000 nM
Compound 3 ended at the assay's limit; the forecaster's own chance of this, stated with the estimate: 55%; at least 1.2-fold (0.07 log units) between middle value and limit.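

In this assay compound 3 gives > 30000 nM, which is a limit of the assay and not a number. Compound 2 also stands at a limit, so no step can be read between compound 2 and compound 3. The compounds shown leave open whether going from methylsulfanyl to octylsulfanyl changes this read-out at all, as all of them share one limit: the limit of > 30000 nM in this assay, at which 3 of the 3 values shown sit.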